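This account rests on a few compounds, and the source may have more. Where it says the series, first, only, none or still open, it means among the compounds named here.

Three compounds built on the shared core of compound 1 `CCc1csc(CN[C@@H]2C[C@H]3C[C@@H]([C@H]2C)C3(C)C)c1` have been examined in an ADME assay on MDCK cells (Canis lupus familiaris) for cytotoxicity, read by microscopy, with a stated time of 48 h; on this read-out lower numbers stand for higher toxicity in this test and higher numbers for lower toxicity in this test. In this assay compound 1 gives 25000 nM. Compound 2 `C[C@H]1[C@H](NCc2cc(C3CC3)cs2)C[C@H]2C[C@@H]1C2(C)C` gives 25000 nM, and compound 3 `C[C@H]1[C@H](NCc2cc(-c3ccsc3)cs2)C[C@H]2C[C@@H]1C2(C)C` gives 25000 nM. The steps among them are no change at the digits printed from compound 1 to compound 2 (within the scatter), no change at the digits printed from compound 1 to compound 3 (within the scatter) and no change at the digits printed from compound 2 to compound 3 (within the scatter), so compound 3 stands level with compounds 1 and 2 at the digits shown, and no compound of the three can be singled out on this read-out.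

Compound 4 `C[C@H]1[C@H](NCc2cc(C3CCCCC3)cs2)C[C@H]2C[C@@H]1C2(C)C` is the next to be measured. The change from compound 3 is cyclohexyl in place of thiophen-3-yl on an aromatic carbon. Among the measured compounds shown here, the steps that bear on this change are those that swap the group on the same aromatic carbon, no change at the digits printed from compound 1 to compound 3 (within the scatter) and no change at the digits printed from compound 2 to compound 3 (within the scatter), together with no change at the digits printed from compound 1 to compound 2 (within the scatter); each of them stayed within the scatter. For the measured compounds named here, a six-membered non-aromatic ring of carbon only at this place has no measured precedent here, but three different groups at the same carbon have so far left this assay unmoved. The estimated step is therefore no change at the digits printed from compound 3 to compound 4 (within the scatter), no change beyond the scatter. Compound 4 is expected to give 25000 nM, within the range 12500 nM to 50000 nM.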

Compound 4, minimum cytotoxic concentration: 780 nM
Beside the measured number, compound 4's estimate is 32-fold (1.51 log units) above it; the measured number lies below the stated range.
By their numbers in this assay, from the lowest: compound 4; then compounds 1, 2 and 3 (each within the scatter of the next).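

At this aromatic carbon, two ring bonds from the ring sulfur, the read-out in this assay does respond to the group, as cyclohexyl brings a 32-fold lower number from compound 3 to compound 4 (1.51 log units; beyond the scatter) and likewise a 32-fold lower number from compound 2 to compound 4 (1.51 log units; beyond the scatter) and a 32-fold lower number from compound 1 to compound 4 (1.51 log units; beyond the scatter) to mark higher toxicity in this test. Ethyl, cyclopropyl and thiophen-3-yl had stayed level with one another at this place, so the earlier compounds gave no sign of this sensitivity, and since two of those groups are themselves rings, carrying a ring here is not enough to lower the number. No measurement shown accounts for the fall seen with the six-membered non-aromatic ring of carbon only.

As far as these compounds go, it remains open whether the drop belongs to cyclohexyl alone or would also appear with neighbouring groups such as cyclopentyl, phenyl, tert-butyl or a longer chain like hexyl. Equally open, from the compounds shown here alone, is whether a hydroxyl group or an amine on the cyclohexyl ring would keep the low number or return it to the level of the other three compounds.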